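Replacing a Hydroxycyclobutyl Group with an Oxanylethyl Chain

The source may report more compounds than this note shows. Statements on the series, on what has been measured and on what is new or still open speak of the compounds shown alone.

Compound 1, `N#Cc1cnc(NCc2cnccc2C(F)(F)F)cc1N[C@H]1C[C@@H](O)C1`: 70%
Compound 2, `N#Cc1cnc(NCc2cnccc2C(F)(F)F)cc1NC[C@H]1C[C@@H](O)C1`: 44%
Compound 3, `N#Cc1cnc(NCc2cnccc2C(F)(F)F)cc1N[C@H]1CC[C@H](O)CC1`: 25%

Of the compounds shown here, three sharing one core have been tested in an ADME assay on S9 fraction from liver (Rattus norvegicus) for metabolic stability, with a stated time of 1 h; on this read-out higher numbers stand for a more stable compound and lower numbers for a less stable compound. Compound 1 stands highest of the three: its nearest neighbour is compound 2, with a number 26 percentage points lower from compound 1 to compound 2 (beyond the scatter), and its furthest is compound 3, with a number 45 percentage points lower from compound 1 to compound 3 (beyond the scatter). Between the two lower compounds the gap is a number 19 percentage points lower from compound 2 to compound 3 (beyond the scatter).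

Compound 4, `N#Cc1cnc(NCc2cnccc2C(F)(F)F)cc1NCCC1CCOCC1`, has not yet been measured in this assay. It differs from compound 1 in one place: 2-(oxan-4-yl)ethyl in place of 3-hydroxycyclobutyl on a nitrogen on an aromatic ring.

Both measured steps away from compound 1 bear on this change, since each puts a larger group in the same place on the nitrogen, and each lowered the reading, one modestly and one by a large amount. The group entering in compound 4 is larger again than either of those, so a drop beyond the scatter is expected, probably at least as deep as the modest one and possibly near the large one. Compound 4 is therefore expected to give 30%, within a range from 10% to 55%, which is expected to amount to a number 40 percentage points lower from compound 1 to compound 4 (beyond the scatter).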

Compound 4, percent of the compound remaining: 0%
Compound 4: middle estimate off by 30 percentage points, on the high side, and the stated range ends above it.
By their numbers in this assay, from the lowest: compound 4; then compound 3; then compound 2; then compound 1.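

In this assay the 2-(oxan-4-yl)ethyl group gives the lowest reading of the four, with a number 70 percentage points lower from compound 1 to compound 4 (beyond the scatter) as the full drop, and it also falls well under both other hydroxylated groups, with a number 44 percentage points lower from compound 2 to compound 4 (beyond the scatter) and a number 25 percentage points lower from compound 3 to compound 4 (beyond the scatter) as the gaps to them. Going by these compounds alone, this is also the first change here that does more than alter the size or reach of the group on the nitrogen: the hydroxyl of the earlier compounds is gone, the hydrogen-bond donor count goes to 0, and the one oxygen now sits inside a six-membered ring. Across these four compounds the reading falls as the group grows, with none going against that order, but nothing in the data shown gives a measured reason for this fall.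

On these data alone, compound 4 changes size, chain length and the hydroxyl group in one step, so the share of each in the result remains open. A 2-(4-hydroxycyclohexyl)ethyl chain, which keeps the hydroxyl on a long chain, and an oxan-4-yl group directly on the nitrogen, which keeps the ring oxygen without the chain, would pull these apart.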